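The source may hold more compounds than are shown below. What is called first, only, known or untested is meant among the compounds shown, and "the series" means these compounds.

Measured so far in an assay on isolated protein for inhibition of Rho-associated protein kinase 1 (Homo sapiens), read by scintillation counting, radiometric assay and 33P incorporation, with a stated time of 40 min, in the presence of a further agent that is not named here; a lower number here means a stronger inhibitor, a higher number a weaker inhibitor:
Compound 1 `CN(C)c1ccc(C(=O)Nc2cccc(NC(=O)COc3ccc4c(c3)OCCO4)c2)cc1`. In this assay compound 1 returns only a limit, > 10000 nM.
Compound 2 `CC(=O)Nc1cccc(NC(=O)COc2ccc3c(=O)ccoc3c2)c1`. In this assay compound 2 gives 2500 nM.
Compound 3 `Cc1cc(C(=O)Nc2cccc(NC(=O)COc3ccc4c(=O)ccoc4c3)c2)no1`. In this assay compound 3 gives 68 nM.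

Of the two numbers, compound 2 holds the highest. Its nearest neighbour is compound 3, reached by a 37-fold lower number from compound 2 to compound 3 (1.57 log units; beyond the scatter), a large step for a 5-methyl-1,2-oxazol-3-yl in place of methyl on a carbonyl carbon. The third value is a limit: the limit of > 10000 nM in this assay, at which 1 of the 3 values shown sits. Within the data shown here, compound 1 also differs from the others in more than one place, so it offers no single step.

Compound 4 `Cn1ccc(S(=O)(=O)Nc2cccc(NC(=O)COc3ccc4c(=O)ccoc4c3)c2)n1` is not yet measured. It differs from compound 2 as follows: a group of 9 heavy atoms (4 carbon, 2 nitrogen, 2 oxygen, 1 sulfur; one five-membered aromatic ring with 2 hetero atoms) in place of a group of 3 heavy atoms (2 carbon, 1 oxygen; no ring), on a nitrogen on an aromatic ring. Among the measured compounds shown here, the one measured step at this position, from compound 2 to compound 3, replaced the acetyl with a ring-bearing group and was large in the lowering direction. For the measured compounds named here, compound 4 again carries a ring-bearing group where compound 2 has acetyl, but with a sulfonyl rather than a carbonyl link, for which no measured step exists. A lowering beyond the scatter is therefore expected, though with less confidence than for compound 3, and a broad range is kept.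

Compound 4 is expected to give about 400 nM, within 80 nM to 2500 nM. The expected step is a 6.3-fold lower number from compound 2 to compound 4 (0.80 log units; beyond the scatter).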

Compound 4, half-maximal inhibitory concentration: > 10000 nM
Compound 4: a limit, no number (the forecaster's own chance of this, stated with the estimate: 10%); middle value at least 25-fold (1.39 log units) away from the limit.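

Among these compounds, at this nitrogen on an aromatic ring, a five-membered aromatic ring with 2 hetero atoms does not by itself bring the lowering seen in the earlier step, since the sulfonyl-linked group gives an at least 4.0-fold higher number from compound 2 to compound 4 (0.60 log units; beyond the scatter) and so runs the opposite way to the only previous step at this position. Against the carbonyl-linked 5-methyl-1,2-oxazol-3-yl group, the gap is wider still, with an at least 140-fold higher number from compound 3 to compound 4 (2.16 log units; beyond the scatter) for a change between two groups that each carry one five-membered aromatic ring with 2 hetero atoms, which makes this position sensitive to more than the presence of such a ring. Compound 4 returns a limit and no number, so both steps are bounds only: the limit of > 10000 nM in this assay, at which 2 of the 4 values shown sit.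

The compounds shown do not separate the link from the ring, as the sulfonyl and the ring differ together between the two groups, and a carbonyl-linked form of the ring in compound 4 or a sulfonyl-linked 5-methyl-1,2-oxazol-3-yl group would pull the two apart. As far as these compounds go, it also stays open how a small methylsulfonyl group on this nitrogen, with no ring at all, or an amine on the ring of the 5-methyl-1,2-oxazol-3-yl group would read.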